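The source may hold more compounds than are shown below. What is called first, only, known or untested is meant among the compounds shown, and "the series" means these compounds.

Compound 1 `COc1cc(OC)c2sc(-c3ccc(N/C=C\C(=O)c4ccc(OC)c(O)c4)c(C)c3)nc2c1` carries a hydroxy group on the ketone-bearing ring and in a functional assay on MDA-MB-231 cells (Homo sapiens) for antiproliferative activity, read by sulforhodamine B assay, with a stated time of 48 h (a lower number here means a stronger inhibitor, a higher number a weaker inhibitor), compound 1 gives 3100 nM. Compound 2 `COc1cc(OC)c2sc(-c3ccc(N/C=C\C(=O)c4ccc(OC)c([N+](=O)[O-])c4)c(C)c3)nc2c1` differs from it by nitro in place of hydroxy on an aromatic carbon, and in this assay compound 2 gives 10800 nM, so that a 3.5-fold higher number from compound 1 to compound 2 (0.54 log units; beyond the scatter). Compound 3 `COc1ccc2nc(-c3ccc(N/C=C\C(=O)c4ccc(OC)c(O)c4)cc3)sc2c1` has a different core, and the difference between the two cores is not broken down here; in this assay compound 3 gives 18900 nM, and its values against compound 1 and compound 2 are as the two numbers show. Compound 4 `COc1ccc2nc(-c3ccc(N/C=C\C(=O)c4ccc(OC)c([N+](=O)[O-])c4)cc3)sc2c1` differs from compound 3 by nitro in place of hydroxy on an aromatic carbon, the same change that was made from compound 1 to compound 2, since both place descriptions read alike word for word. For the measured compounds named here, for compound 4 an estimated step of a 2.4-fold higher number from compound 3 to compound 4 (0.38 log units; beyond the scatter) is expected because a 3.5-fold higher number from compound 1 to compound 2 (0.54 log units; beyond the scatter) is the only earlier instance of this change, on a different core, so it is carried over with added uncertainty. Compound 4 is therefore expected to give about 45000 nM, with an expected span from 15000 nM to 130000 nM.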

Compound 4, half-maximal inhibitory concentration: 17600 nM
For compound 4 the middle estimate is 2.6-fold (0.41 log units) above the measured one; the measured number falls inside the stated range.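

In this assay, the change from hydroxy to nitro on the ketone-bearing ring gives a 1.1-fold lower number from compound 3 to compound 4 (0.03 log units; within the scatter) and so does not repeat the step seen on the core of compound 1. These two pairs show only that, in this assay, the step measured on one core cannot be relied on as a guide to its size on the other, and they do not show which feature of the difference between the cores matters or how the step would read on any further core. The size of this change therefore does not transfer between the two cores shown, as the two steps set side by side make plain: the same change on two cores in this assay, a 3.5-fold higher number (0.54 log units; beyond the scatter) from compound 1 to compound 2 and a 1.1-fold lower number (0.03 log units; within the scatter) from compound 3 to compound 4, 3.7-fold (0.57 log units) apart, beyond the scatter of two such steps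

The compounds shown leave open how an amine or a carboxylic acid in place of hydroxy at this position would read on either core. They also leave open whether a third core would follow the pair of compound 1 and compound 2 or the pair of compound 3 and compound 4.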